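Removing the tert-butyl sulfanyl group from a peptidomimetic

The source may hold more compounds than are shown below. What is called first, only, known or untested is meant among the compounds shown, and "the series" means these compounds.

Compound 1 `CN[C@@H](C)C(=O)N[C@@H](CSSC(C)(C)C)C(=O)N1CCC[C@H]1C(=O)NC(c1ccccc1)c1ccccc1` gives 49900 nM in a functional assay on MDA-MB-231 cells (Homo sapiens) for inhibition, with a stated time of 48 h (on this read-out higher numbers stand for an effect only at larger amounts of compound and lower numbers for an effect already at smaller amounts), the highest of the two numbers recorded; compound 2 `CN[C@@H](C)C(=O)N[C@@H](CSCc1ccc(CSC[C@H](NC(=O)[C@H](C)NC)C(=O)N2CCC[C@H]2C(=O)NC(c2ccccc2)c2ccccc2)cc1)C(=O)N1CCC[C@H]1C(=O)NC(c1ccccc1)c1ccccc1` gives 9600 nM in this assay. Compound 3 `CN[C@@H](C)C(=O)N[C@@H](CS)C(=O)N1CCC[C@H]1C(=O)NC(c1ccccc1)c1ccccc1` differs from compound 1 by hydrogen in place of (tert-butyl)sulfanyl on a sulfur. Going by the values given here, no step between measured compounds is available for that change, so the expectation rests on compound 1 alone. Compound 3 is expected to stay near compound 1, with the step of a 1.2-fold higher number from compound 1 to compound 3 (0.08 log units; within the scatter) estimated to lie within or only slightly beyond the scatter. Compound 3 is thus estimated at 60000 nM, in a range from 20000 nM to 180000 nM.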

Compound 3, half-maximal effective concentration: > 100000 nM
Compound 3: only a limit was reported (the forecaster's own chance of this, stated with the estimate: 25%); middle value at least 1.6-fold (0.22 log units) away from the limit.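

Hydrogen in place of (tert-butyl)sulfanyl on a sulfur gives an at least 2.0-fold higher number from compound 1 to compound 3 (0.30 log units; that floor lies within the scatter) in this assay. The change thus brings no gain at this sulfur, though the true size of the step cannot be read. The value of compound 3 is a limit and not a number: the limit of > 100000 nM in this assay, at which 1 of the 3 values shown sits.

On these data alone, whether methyl or a longer chain on this sulfur would bring the number lower remains open. So does how an amine or a carboxylic acid at the end of such a chain would read.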